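The source may hold more compounds than are shown below. What is called first, only, known or untested is meant among the compounds shown, and "the series" means these compounds.

Measured so far:
compound 1 `O=C(OCc1ccccc1)[C@@H]1CCCN1C(=O)CN(c1nc(Cl)nc2[nH]cnc12)C1CC1`, 38.4%
compound 2 `CC[C@H](C)[C@H](NC(=O)CN(c1ncnc2c1ncn2C1CCCCO1)C1CC1)C(=O)OCc1ccccc1`, 20.4%
compound 3 `O=C(O)CNC(=O)CN(c1nc(Cl)nc2[nH]cnc12)C1CC1`, 19.8%

All three were tested in a functional assay on the whole organism (Tail, strain ICR) with Mus musculus as the target, in the tail flick test, with a stated time of 120 min, at a dose of 25 umol/kg by the oral route; a higher number here means a stronger effect of the compound at the dose given, a lower number a weaker effect. Compound 2 stands second highest of the three numbers: its value lies within the scatter of the value of compound 3, so no order between those two can be read, while compound 1 lies beyond the scatter above it.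

Compound 4 `CSCC[C@H](NC(=O)CN(c1ncnc2c1ncn2C1CCCCO1)C1CC1)C(=O)OCc1ccccc1` differs from compound 2 in one place: 2-(methylsulfanyl)ethyl in place of sec-butyl on a saturated chain carbon bound to an amide-type nitrogen and a carbonyl carbon. Among the measured compounds shown here, no measured pair shows a change of this kind, so there is nothing to calibrate its effect. The expected step of a number 1.6 percentage points higher from compound 2 to compound 4 (within the scatter) is small, without a direction beyond the scatter. Compound 4 is expected to give about 22%, with a likely range from 8% to 38%.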

Compound 4, a percentage reported as activity, at one dose (the size of the read-out at that dose, not a potency): 28.7%
Compound 4: the middle estimate sits 6.7 percentage points below what was measured; measured number inside the range.
By their numbers in this assay, from the lowest: compounds 3, 2, 4 and 1 (each within the scatter of the next, the first and the last beyond it).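

In this assay, placing 2-(methylsulfanyl)ethyl instead of sec-butyl on the saturated chain carbon gives a number 8.3 percentage points higher from compound 2 to compound 4 (within the scatter). This single pair therefore shows that this position accepts a sulfur-containing chain in place of a branched all-carbon one with no loss beyond the scatter at this dose. Nothing available explains the step. On these data alone, whether an amine, a carboxylic acid or a longer chain at this position would shift the effect beyond the scatter remains open. So does whether this exchange would behave the same way on a different core.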